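A few compounds are considered here, and "the series" means these few. Any claim that something is new, unique, unknown or untested is made for them only; others in the source may bear on it.

In an ADME assay on Caco-2 cells (Homo sapiens) for permeability, read by LC-MS, in the apical to basolateral direction, with a stated time of 60 min, at pH 6.5 (a lower number here means that the compound crosses the layer more slowly, a higher number that the compound crosses the layer faster), compound 1 `CC(C)(C)OC[C@@H](O)C(=O)N1[C@H](C(=O)NCc2cc(Cl)ccc2-n2cnnn2)C[C@@H]2C[C@@H]21` gives 4.5 10^-6 cm/s, compound 2 `O=C(NCc1cc(Cl)ccc1-n1cnnn1)[C@@H]1C[C@H]2C[C@H]2N1C(=O)[C@H](O)c1ccccc1` gives 17 10^-6 cm/s and compound 3 `O=C(NCc1cc(Cl)ccc1-n1cnnn1)[C@@H]1C[C@@H]2C[C@@H]2N1C(=O)[C@H](O)c1ccccc1F` gives 16 10^-6 cm/s. Compound 3 thus lies within the scatter of compound 2 and well clear of compound 1. Compound 4 `O=C(NCc1cc(Cl)ccc1-n1cnnn1)[C@@H]1C[C@@H]2C[C@@H]2N1C(=O)[C@H](O)c1ccccc1` differs from compound 3 by one small edit, hydrogen in place of fluoro on an aromatic carbon. For the measured compounds named here, the only measured step that bears on this is a 3.6-fold higher number from compound 1 to compound 3 (0.55 log units; beyond the scatter), and it swapped a whole (tert-butoxy)methyl for 2-fluorophenyl, so it does not isolate the fluoro. Going by the values given here, no measured step removes a fluoro alone, so nothing beyond the scatter is expected in this assay, and the estimated step is no change at the digits printed from compound 3 to compound 4 (within the scatter). Compound 4 is expected at 16 10^-6 cm/s, with an estimated range of 8 10^-6 cm/s to 30 10^-6 cm/s.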

Compound 4, apparent permeability: 8 10^-6 cm/s
Beside the measured number, compound 4's estimate is 2.0-fold (0.30 log units) above it; measured number inside the range.
By their numbers in this assay, from the lowest: compounds 1, 4, 3 and 2 (each within the scatter of the next, the first and the last beyond it).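

In this assay, taking away the fluoro gives a 2.0-fold lower number from compound 3 to compound 4 (0.30 log units; within the scatter) and so shows no clear effect at this aromatic carbon. Phenyl in place of (tert-butoxy)methyl gives a 1.8-fold higher number from compound 1 to compound 4 (0.25 log units; within the scatter), so unlike 2-fluorophenyl, plain phenyl stays within the scatter of that chain. Yet a 2.1-fold lower number from compound 2 to compound 4 (0.33 log units; beyond the scatter) arises with no change of atoms, from configuration alone, as shown by: the fact that compounds 2 and 4 differ only in the configuration as drawn.

Still open, from the compounds shown here alone, is whether a chloro, a methoxy or an amine on that aromatic carbon would move the number beyond the scatter. Also open, going by these compounds, is how 2-fluorophenyl behaves in the configuration of compound 2.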